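This account rests on a few compounds, and the source may have more. Where it says the series, first, only, none or still open, it means among the compounds named here.

Compound 2 `COc1cccc(CNCCCNc2ccnc3cc(CCc4ccccc4)ccc23)c1O` gives 4200 nM in a physicochemical assay for solubility, with a stated time of 18 h, at pH 7.4; on this read-out higher numbers stand for higher solubility and lower numbers for lower solubility; compound 1 `COc1cccc(CNCCCNc2ccnc3cc(Cc4ccc(C#N)cc4)ccc23)c1O` gives 4200 nM in this assay, and the step of no change at the digits printed from compound 1 to compound 2 (within the scatter) lies within the scatter, so compound 2 stands level with compound 1. Compound 3 `COc1cccc(CNCCCNc2ccnc3cc(-c4cccc5ccccc45)ccc23)c1O` differs from compound 2 by naphthalen-1-yl in place of phenethyl on an aromatic carbon. Going by the values given here, only one measured step bears on this, the step from compound 1 to compound 2, which was flat; it concerns a different replacement, so it carries limited weight here. The expected step is a 1.7-fold lower number from compound 2 to compound 3 (0.23 log units; within the scatter), a modest decrease or none beyond the scatter. Compound 3 is expected to give 2500 nM, within 800 nM to 6000 nM.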

Compound 3, solubility: 32000 nM
The estimate for compound 3 lay 13-fold (1.11 log units) below the measured number; the measured number lies above the stated range.
By their numbers in this assay, from the lowest: compounds 1 and 2 (each within the scatter of the next); then compound 3.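

In this assay this aromatic carbon proves sensitive to the group it carries: naphthalen-1-yl in place of phenethyl gives a 7.6-fold higher number from compound 2 to compound 3 (0.88 log units; beyond the scatter) and naphthalen-1-yl in place of 4-cyanobenzyl gives a 7.6-fold higher number from compound 1 to compound 3 (0.88 log units; beyond the scatter) here. The earlier pair, phenethyl and 4-cyanobenzyl, stood level, so that flat step did not extend to this replacement. Nothing available explains the rise.

On these data alone, whether the second ring of naphthalen-1-yl or the loss of the saturated chain carries the step stays open. So does the outcome with phenyl or an amine on this carbon.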